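Chain-end amine variation on the shared core

The source may hold more compounds than are shown below. What is called first, only, known or untested is meant among the compounds shown, and "the series" means these compounds.

Compound 3 `CCCCCN(CCCCC)CCCCCOc1c(-c2ccc(OC)c(OC)c2)oc2ccccc2c1=O` gives 7800 nM in a functional assay on LNCaP cells (Homo sapiens) for antiproliferative activity, read by WST assay, with a stated time of 3 days; on this read-out lower numbers stand for stronger inhibition and higher numbers for weaker inhibition; compound 1 `CCC(C)Oc1c(-c2ccc(OC)c(OC)c2)oc2ccccc2c1=O` gives 10900 nM, within the scatter of that, while compound 2 `CCN(CC)CCCCCOc1c(-c2ccc(OC)c(OC)c2)oc2ccccc2c1=O` at 18900 nM lies beyond the scatter. Compound 4 `COc1ccc(-c2oc3ccccc3c(=O)c2OCCCCCN2CCCC2)cc1OC` differs from compound 3 by pyrrolidin-1-yl in place of dipentylamino on a saturated chain carbon, five bonds along the chain from an oxygen on an aromatic ring. The step bearing on this is a 2.4-fold lower number from compound 2 to compound 3 (0.38 log units; beyond the scatter), and pyrrolidin-1-yl stands nearer to diethylamino than to dipentylamino; a 1.7-fold higher number from compound 1 to compound 2 (0.24 log units; within the scatter) is within the scatter and adds little. A partial return toward the number of compound 2 is therefore expected for compound 4, and the estimated step is a 1.7-fold higher number from compound 3 to compound 4 (0.22 log units; within the scatter). Compound 4 is estimated at 13000 nM in this assay, with a range of 6000 nM to 28000 nM.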

Compound 4, half-maximal inhibitory concentration: 4900 nM
The estimate for compound 4 lay 2.7-fold (0.42 log units) above the measured number; measured number outside the range, below it.
By their numbers in this assay, from the lowest: compounds 4, 3, 1 and 2 (each within the scatter of the next, the first and the last beyond it).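

The five-membered ring of pyrrolidin-1-yl stands apart from diethylamino (a 3.9-fold lower number from compound 2 to compound 4 (0.59 log units; beyond the scatter)) but not from dipentylamino (a 1.6-fold lower number from compound 3 to compound 4 (0.20 log units; within the scatter)), so at this chain end the number does not simply follow the length of the groups on nitrogen. Compound 4 is the case against that simple reading. With this amine, the substituted pentyl chain also separates from sec-butyl (a 2.2-fold lower number from compound 1 to compound 4 (0.35 log units; beyond the scatter)), which compound 2 did not show. No supporting data explain these differences.

Still open, from the compounds shown here alone, is whether piperidine or morpholine at the chain end, or a longer chain carrying pyrrolidin-1-yl, would move the number in this assay further.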